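Replacing the Aryl Group on a Shared Carbonyl Carbon

The source may report more compounds than this note shows. Statements on the series, on what has been measured and on what is new or still open speak of the compounds shown alone.

Compound 1 `COc1ccc(-c2cc3ccccc3nc2/C=C/C(=O)c2ccc(OC)c(OC)c2)cc1` gives 8860 nM in a functional assay on A549 cells (Homo sapiens) for antiproliferative activity, read by XTT assay, with a stated time of 72 h; on this read-out lower numbers stand for stronger inhibition and higher numbers for weaker inhibition. Compound 2 `COc1ccc(-c2cc3ccccc3nc2/C=C/C(=O)c2cccs2)cc1` gives 920 nM in this assay. Compound 3 `COc1ccc(-c2cc3ccccc3nc2/C=C/C(=O)c2cnc(N)nc2C)cc1` reaches only a limit of this assay, > 10000 nM, and so carries no definite number (the limit of > 10000 nM in this assay, at which 1 of the 3 values shown sits). Compound 4 `COc1ccc(-c2cc3ccccc3nc2/C=C/C(=O)c2c[nH]c3ccccc23)cc1` differs from compound 3 by 1H-indol-3-yl in place of 2-amino-4-methylpyrimidin-5-yl on a carbonyl carbon. Among the compounds with values here, two measured steps bear on this change: an at least 1.1-fold higher number from compound 1 to compound 3 (0.05 log units; that floor lies within the scatter) and an at least 10-fold higher number from compound 2 to compound 3 (1.03 log units; beyond the scatter). One lies within the scatter, the other beyond it, so moving away from the pyrimidine toward a carbon-rich aromatic group is expected to lower the number, with an estimated step of an at least 4.0-fold lower number from compound 3 to compound 4 (0.60 log units; beyond the scatter). Compound 4 is therefore expected to give about 2500 nM, with a likely range from 600 nM to 10000 nM.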

Compound 4, half-maximal inhibitory concentration: > 10000 nM
Compound 4 gave a limit, no number; the forecaster's own chance of this, stated with the estimate: 20%; middle value at least 4.0-fold (0.60 log units) from the limit.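

Changing thiophen-2-yl to 1H-indol-3-yl on this carbonyl carbon weakens the result in this assay, with an at least 10-fold higher number from compound 2 to compound 4 (1.03 log units; beyond the scatter), so a carbon-rich aromatic group does not by itself keep the activity of compound 2. Against the 3,4-dimethoxyphenyl group the change gives an at least 1.1-fold higher number from compound 1 to compound 4 (0.05 log units; that floor lies within the scatter), and that floor separates the two compounds by nothing readable. The step between compound 3 and compound 4 cannot be read, since both sit at the same assay limit: the limit of > 10000 nM in this assay, at which 2 of the 4 values shown sit.

On these data alone, how far past that limit either compound lies stays unknown. As far as these compounds go, whether a furan-2-yl or an unsubstituted phenyl group on this carbon would match thiophen-2-yl also remains open.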